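A few compounds are considered here, and "the series" means these few. Any claim that something is new, unique, unknown or untested is made for them only; others in the source may bear on it.

Compound 1 `Cc1ccccc1Cn1cc(COc2ccc3c(=O)ccoc3c2)nn1` and compound 2 `C#CCOc1ccc2c(=O)ccoc2c1` share the same core. In a functional assay on SW480 cells (Homo sapiens) for cytotoxicity, read by MTT assay, with a stated time of 48 h (a lower number here means a stronger inhibitor, a higher number a weaker inhibitor), compound 1 reports only a limit, > 100000 nM. Compound 2 likewise gives only a limit, > 100000 nM. Compound 1 therefore stands nowhere distinct on the numbers shown, both values being limits. Compound 3 `COc1ccc(Cn2cc(COc3ccc4c(=O)ccoc4c3)nn2)cc1` differs from compound 1 by 4-methoxyphenyl in place of 2-methylphenyl on a saturated chain carbon bound to an aromatic nitrogen. Among the compounds with values here, no step between measured compounds is known. Compound 1 already sits at the limit of > 100000 nM in this assay, at which 2 of the 2 values shown sit. The step in this assay is thus expected to be none beyond the scatter, a step that the limit leaves unreadable from compound 1 to compound 3. Compound 3 is expected near 150000 nM, within 50000 nM to 500000 nM, most likely reported again as a limit.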

Compound 3, half-maximal inhibitory concentration: 20400 nM
Compound 3: the middle estimate sits 7.4-fold (0.87 log units) above what was measured; the whole stated range lies above it.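

In this assay, within the data shown here, this position is the first to give a readable number: 4-methoxyphenyl in place of 2-methylphenyl on a saturated chain carbon bound to an aromatic nitrogen brings an at least 4.9-fold lower number from compound 1 to compound 3 (0.69 log units; beyond the scatter) in a single change. The group at this position therefore does register in this assay. The size of the step remains a minimum, because its starting point is only a limit: the limit of > 100000 nM in this assay, at which 2 of the 3 values shown sit.

The compounds shown leave open whether the methoxy group or its place carries the step, which 4-methylbenzyl or 2-methoxybenzyl would separate. Going by these compounds, how an amine or a carboxylic acid at this position would read also remains open.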